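A Sulfur Substituent Swap in Bromophenyl Enones

The compounds below may be only part of what the source reports. "The series", "measured", "known", "first", "only" and "open" are said of these compounds alone.

Compound 2 `CN(C)c1ccc(/C=C(/SCc2ccc(Cl)cc2)C(=O)c2ccc(Br)cc2)cc1` stands as the weaker of the two measured inhibitors: in a functional assay on DU-145 cells (Homo sapiens) for inhibition, read by trypan blue exclusion, with a stated time of 96 h (a lower number here means a stronger inhibitor of growth, a higher number a weaker inhibitor of growth), compound 2 gives 10000 nM. For the measured compounds named here, compound 3 `COc1ccc(/C=C(/SCc2ccc(Cl)cc2)C(=O)c2ccc(Br)cc2)cc1O` gives 1000 nM in this assay, and the single measured step, a 10-fold lower number from compound 2 to compound 3 (1.00 log units; beyond the scatter), changes the aromatic ring on the chain rather than the group on the sulfur. Compound 1 `O=C(/C(=C\c1c(O)cc(O)cc1O)Sc1ccccc1Br)c1ccc(Br)cc1` in this assay gives only a limit, > 100000 nM. That value is the limit of > 100000 nM in this assay, at which 1 of the 3 values shown sits. Compound 4 `CN(C)c1ccc(/C=C(/Sc2ccccc2Br)C(=O)c2ccc(Br)cc2)cc1` differs from compound 2 by 2-bromophenyl in place of 4-chlorobenzyl on a sulfur. Going by the values given here, no measured step alters this group, so the expected step of a 2.0-fold higher number from compound 2 to compound 4 (0.30 log units; within the scatter) is small and uncertain. Compound 4 is estimated at 20000 nM in this assay, in a range from 4000 nM to 100000 nM.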

Compound 4, concentration for 50% growth inhibition: > 100000 nM
Compound 4 ended at the assay's limit (the forecaster's own chance of this, stated with the estimate: 25%); middle value at least 5.0-fold (0.69 log units) away from the limit.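

Putting 2-bromophenyl in place of 4-chlorobenzyl on the sulfur gives an at least 10-fold higher number from compound 2 to compound 4 (1.00 log units; beyond the scatter), so the sulfur substituent, which the earlier step left unchanged, can also shift growth inhibition beyond the scatter. Compound 4 gives a limit and not a number: the limit of > 100000 nM in this assay, at which 2 of the 4 values shown sit. The step between compound 1 and compound 4 cannot be read.

The compounds shown do not separate the change from benzyl to phenyl from the change of halogen. A 2-bromobenzyl or a 4-chlorophenyl group on the sulfur could tell these two changes apart.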